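Trimming a carbamate: aryl to ethyl on the nitrogen

This account rests on a few compounds, and the source may have more. Where it says the series, first, only, none or still open, it means among the compounds named here.

Of the compounds shown here, two have been measured in an assay on frontal cortex for displacement of a labelled ligand from corticotropin-releasing factor receptor 1 (Rattus norvegicus), with a stated time of 2 h; on this read-out lower numbers stand for stronger inhibition and higher numbers for weaker inhibition. Compound 1 `COc1nc(C)c(Nc2nc(Cl)cn([C@H](COC(=O)c3ccccc3)C3CC3)c2=O)cc1C` carries a benzoate ester on the side chain, and in this assay compound 1 gives 1.5 nM. Compound 2 `COc1nc(C)c(Nc2nc(Cl)cn([C@H](COC(=O)Nc3cccc(C#N)c3)C3CC3)c2=O)cc1C` replaces that ester with a carbamate bearing a 3-cyanophenyl group, and compound 2 gives 1.3 nM. Within the data shown here, the only measured step, a 1.2-fold lower number from compound 1 to compound 2 (0.06 log units; within the scatter), shows that swapping the group on the carbonyl carbon left the number essentially unchanged. Compound 2 therefore stands with the lowest of the two numbers, yet its nearest neighbour, compound 1, sits within the scatter of it.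

Compound 3 `CCNC(=O)OC[C@H](C1CC1)n1cc(Cl)nc(Nc2cc(C)c(OC)nc2C)c1=O` keeps the carbamate but changes its nitrogen substituent: ethyl in place of 3-cyanophenyl on an amide-type nitrogen. Among the measured compounds shown here, no measured step covers this exact exchange. For the measured compounds named here, the one step available, from a phenyl to a (3-cyanophenyl)amino group on the carbonyl carbon, was within the scatter, which suggests this outer part of the molecule tolerates alteration. On that basis compound 3 is expected to show a 2.3-fold higher number from compound 2 to compound 3 (0.36 log units; beyond the scatter), a small shift toward a higher number that may well fall within the scatter. The estimate for compound 3 in this assay is 3 nM, with a range from 1 nM to 10 nM.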

Compound 3, half-maximal inhibitory concentration: 14 nM
Estimate against measurement, compound 3: 4.7-fold (0.67 log units) below, and the stated range ends below it.
By their numbers in this assay, from the lowest: compounds 2 and 1 (each within the scatter of the next); then compound 3.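

In this assay, the outer end of this side chain proves less forgiving than the earlier pair suggested, with the swap on the amide-type nitrogen giving a clear loss (an 11-fold higher number from compound 2 to compound 3 (1.03 log units; beyond the scatter)). Ethyl in place of 3-cyanophenyl removes the six-membered aromatic ring and the triple bond of the nitrile together, shrinking the group from 8 heavy atoms to 2. The comparison with the benzoate ester points the same way (a 9.3-fold higher number from compound 1 to compound 3 (0.97 log units; beyond the scatter)), so among these three compounds, the two with an aromatic ring at this end lie within the scatter of each other, while the one without a ring there stands apart.

No measurement shown here bears on the reason for this loss. Going by these compounds, it remains open whether the ring itself matters or simply the size of the group, a question that an unsubstituted phenyl, a cyclohexyl ring or a longer chain such as butyl on the same nitrogen could help to settle.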